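The compounds below may be only part of what the source reports. "The series", "measured", "known", "first", "only" and "open" are said of these compounds alone.

Measured in an assay on HEK293 cells for inhibition of Voltage-dependent N-type calcium channel subunit alpha-1B (Homo sapiens), read by fluorescence and calcium flux, with a stated time of 5 min; a lower number here means a stronger inhibitor, a higher number a weaker inhibitor:
compound 1, `COc1ccccc1-n1nc([C@H]2C[C@@H](C)O[C@@H](C)C2)cc1-c1ccc(Cl)cc1`: 3 nM
compound 2, `COc1ccccc1-n1nc(C2CC(C)(C)OC(C)(C)C2)cc1-c1ccc(C#N)cc1`: 1 nM

Compound 2 gives the lowest number of the two in this assay; compound 1 gives a higher number, beyond the scatter. Going by the values given here, the two differ in more than one place, so no single step between them is on record. Compound 3, `COc1ccccc1-n1nc(C2CC(C)(C)OC(C)(C)C2)cc1-c1ccc(C)nc1`, is not yet measured; it differs from compound 2 by 6-methylpyridin-3-yl in place of 4-cyanophenyl on an aromatic carbon. Among the compounds with values here, the expected step is a 3.0-fold higher number from compound 2 to compound 3 (0.48 log units; beyond the scatter), a modest rise in this assay, with sizable uncertainty as no comparable step is available. Compound 3 is estimated at 3 nM, with a range from 1 nM to 12 nM.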

Compound 3, half-maximal inhibitory concentration: 6 nM
Compound 3: the middle estimate sits 2.0-fold (0.30 log units) below what was measured; low and high end bracket the measured number.
By their numbers in this assay, from the lowest: compound 2; then compounds 1 and 3 (each within the scatter of the next).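

In this assay the aromatic carbon two ring bonds from the ring atom that bears the 2,2,6,6-tetramethyloxan-4-yl group takes 6-methylpyridin-3-yl in place of 4-cyanophenyl with a 6.0-fold higher number from compound 2 to compound 3 (0.78 log units; beyond the scatter) as the cost. The nitrile is therefore not required for activity at this position, since compound 3 still reads 6 nM without it. As far as these compounds go, the change alters the ring and its substituent together, so the share of each stays open; a 4-methylphenyl or an unsubstituted pyridin-3-yl group would separate them. No measurement at hand accounts for the rise.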